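A few compounds are considered here, and "the series" means these few. Any claim that something is new, unique, unknown or untested is made for them only; others in the source may bear on it.

Measured compounds in a functional assay on 4T1 cells (Homo sapiens) for cytotoxicity, read by MTT assay, with a stated time of 48 h; on this read-out higher numbers stand for weaker inhibition and lower numbers for stronger inhibition:
Compound 1, `CC(C)n1c(/C=C2/C(=O)Nc3ccccc32)nc2ccccc21`: 40400 nM.
Compound 2, `CCn1c(/C=C2/C(=O)Nc3ccccc32)nc2ccccc21`: > 50000 nM, which is a limit of the assay, not a number.
Compound 3, `Cn1c(/C=C2/C(=O)Nc3ccc(Br)cc32)nc2ccccc21`: > 50000 nM, which is likewise a limit of the assay, not a number.

Compound 1 is the only one of the three that gives a number at all; the other two values are limits, as shown by the limit of > 50000 nM in this assay, at which 2 of the 3 values shown sit. Among the compounds with values here, the single step that changes one place, an at least 1.2-fold higher number from compound 1 to compound 2 (0.09 log units; that floor lies within the scatter), has a floor small enough to sit within the usual scatter, so it says little about direction.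

Compound 4, `CC(C)n1c(/C=C2/C(=O)Nc3ccc(F)cc32)nc2ccccc21`, differs from compound 1 by fluoro in place of hydrogen on an aromatic carbon. Within the data shown here, no measured step in this set touches that change: compound 3 differs from compound 1 in more than one place, and its value is only a limit. With nothing to lean on, the expected step in this assay is none beyond the scatter. Compound 4 is therefore expected at about 40000 nM, with a range from 15000 nM to 100000 nM. That expectation corresponds to a step of a 1.0-fold lower number from compound 1 to compound 4 (0.00 log units; within the scatter).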

Compound 4, half-maximal inhibitory concentration: 25800 nM
Estimate against measurement, compound 4: 1.6-fold (0.19 log units) above; the measured number falls inside the stated range.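

In this assay, fluoro on this aromatic carbon gives a 1.6-fold lower number from compound 1 to compound 4 (0.19 log units; within the scatter). Within the data shown here, this is the first step at this position that can be read directly, and it shows that fluoro can replace hydrogen here without a change that stands out from ordinary repeat variation. Compound 4 also joins compound 1 in giving an actual number, while the other compounds shown give only a limit: the limit of > 50000 nM in this assay, at which 2 of the 4 values shown sit.

As far as these compounds go, whether chloro, methoxy, an amine or a carboxylic acid on this same carbon would move the number beyond the scatter remains open. From the compounds shown here alone, it is also open whether a longer chain, such as butyl, on the aromatic nitrogen would change the number of compound 4.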